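The source may report more compounds than this note shows. Statements on the series, on what has been measured and on what is new or still open speak of the compounds shown alone.

Compounds measured in a functional assay on ECa-109 cells (Homo sapiens) for antiproliferative activity, read by MTT assay, with a stated time of 72 h; a higher number here means a weaker inhibitor, a lower number a stronger inhibitor:

Compound 1, `CCCSc1nc(N/N=C(\C)c2ccc(O)cc2)c2nnn(Cc3ccccc3)c2n1`, gives 32500 nM.
Compound 2, `CCCSc1nc(N/N=C(\C)c2ccccc2O)c2nnn(Cc3ccc(F)cc3)c2n1`, gives 21900 nM.
Compound 3, `CCCSc1nc(N/N=C(\C)c2ccccc2O)c2nnn(Cc3ccco3)c2n1`, gives 5760 nM.

Among these three, compound 1 carries the highest number. Its nearest neighbour is compound 2, whose value lies within the scatter of it, so no order between the two can be claimed; compound 3 lies beyond the scatter, with the lower number. Within the data shown here, the one measured step, a 3.8-fold lower number from compound 2 to compound 3 (0.58 log units; beyond the scatter), concerns the group on the saturated chain carbon bound to an aromatic nitrogen and so does not touch the part changed here.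

Compound 4, `CCCSc1nc(N/N=C(\C)c2ccc(Br)cc2)c2nnn(Cc3ccccc3)c2n1`, differs from compound 1 in one place: bromo in place of hydroxy on an aromatic carbon on an aromatic carbon of a six-membered aromatic ring of carbon only, para to a large group. Among the measured compounds shown here, no measured pair shows this exchange, so there is no step from which its size can be read. The expected outcome is therefore a step of a 1.3-fold lower number from compound 1 to compound 4 (0.11 log units; within the scatter), not clearly beyond the scatter in either direction, and compound 4 is estimated at 25000 nM, within the range 8000 nM to 80000 nM.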

Compound 4, half-maximal inhibitory concentration: 4670 nM
Compound 4: the middle estimate sits 5.4-fold (0.73 log units) above what was measured, and the stated range ends above it.
By their numbers in this assay, from the lowest: compounds 4 and 3 (each within the scatter of the next); then compounds 2 and 1 (each within the scatter of the next).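

With the group para to a large group on the six-membered aromatic ring, this position proves able to shift the reading in this assay: bromo in place of hydroxy gives a 7.0-fold lower number from compound 1 to compound 4 (0.84 log units; beyond the scatter). Among these compounds, the earlier compounds offered no measured exchange at this place, so this is the first sign that the group held here matters. The change removes the hydrogen-bond donor and hydrogen-bond acceptor counted for hydroxy, but nothing on hand explains why the number falls.

The compounds shown leave open whether chloro, methoxy or an amine at this position would track with bromo or with hydroxy, since two groups define no trend. Going by these compounds, it also remains open whether the same exchange would give a step of similar size alongside the furan-2-yl group of compound 3.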